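The source may hold more compounds than are shown below. What is called first, only, known or untested is meant among the compounds shown, and "the series" means these compounds.

In a functional assay on HeLa cells (Homo sapiens) for antiproliferative activity, read by sulforhodamine B assay (a lower number here means a stronger inhibitor of growth, a higher number a weaker inhibitor of growth), compound 1 (`O[C@H]1CO[C@H](COCc2ccccc2)[C@@H](OCc2ccccc2)[C@@H]1OCc1ccccc1`) gives > 50000 nM, which is a limit of the assay and not a number. Compound 2 (`CC[C@@H]1O[C@H](COCc2ccccc2)[C@@H](OCc2ccccc2)[C@H](OCc2ccccc2)[C@H]1O`) gives 19800 nM. Compound 3 (`OCC[C@@H]1O[C@H](COCc2ccccc2)[C@@H](OCc2ccccc2)[C@H](OCc2ccccc2)[C@H]1O`) gives 30200 nM, and these last two values lie within the scatter of each other. Compound 4 (`O[C@@H]1[C@@H](OCc2ccccc2)[C@H](OCc2ccccc2)[C@@H](COCc2ccccc2)O[C@H]1CC1CCCCC1`) is still unmeasured. Its difference from compound 3 is cyclohexyl in place of hydroxymethyl on a saturated chain carbon bound to a saturated ring carbon. Read one bond further out, this is 2-hydroxyethyl to cyclohexylmethyl.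

Going by the values given here, three measured steps bear on this. Ethyl on the ring carbon gave an at least 2.5-fold lower number from compound 1 to compound 2 (0.40 log units; beyond the scatter), while 2-hydroxyethyl there gave an at least 1.6-fold lower number from compound 1 to compound 3 (0.21 log units; that floor lies within the scatter), whose floor stays within the scatter. The hydroxy on the chain gave a 1.5-fold higher number from compound 2 to compound 3 (0.18 log units; within the scatter), so removing it from compound 3 is expected to count for little. Among the compounds with values here, no measured step covers a ring on this chain, so the expectation is loose: a small move in this assay towards a lower number, near the edge of the scatter.

The expected change is a 2.0-fold lower number from compound 3 to compound 4 (0.30 log units; within the scatter).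

For compound 4 the estimate is 15000 nM, with an expected range of 5000 nM to 45000 nM.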

Compound 4, concentration for 50% growth inhibition: 9500 nM
Estimate against measurement, compound 4: 1.6-fold (0.20 log units) above; the range from low to high includes it.
By their numbers in this assay, from the lowest: compound 4; then compounds 2 and 3 (each within the scatter of the next). At a limit, above all of these: compound 1.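

In this assay, cyclohexylmethyl on the saturated ring carbon separates from both smaller chains, giving a 3.2-fold lower number from compound 3 to compound 4 (0.50 log units; beyond the scatter) and a 2.1-fold lower number from compound 2 to compound 4 (0.32 log units; beyond the scatter), whereas ethyl and 2-hydroxyethyl at this place stayed within the scatter of each other. A ring on this chain therefore gives a change beyond the scatter, and compound 4 is the strongest inhibitor of growth among the four compounds. The third step, an at least 5.2-fold lower number from compound 1 to compound 4 (0.72 log units; beyond the scatter), starts from a value for compound 1 that is a limit and not a number: the limit of > 50000 nM in this assay, at which 1 of the 4 values shown sits.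

Going by these compounds alone, with only one ring-bearing chain, the effect of the ring cannot be separated from that of the added carbons. As far as these compounds go, whether phenyl, a longer straight alkyl chain or an amine on this chain would match cyclohexylmethyl remains open.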